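Benzoyl replaces 4-methoxybenzyl on compound 3

This account rests on a few compounds, and the source may have more. Where it says the series, first, only, none or still open, it means among the compounds named here.

In a physicochemical assay for solubility, with a stated time of 3 days, at pH 7 (a higher number here means a more soluble compound, a lower number a less soluble compound), compound 3 `COc1ccc(CN2CCC(CCOc3ccc(-c4nc5cc(C(N)=O)ccc5[nH]4)cc3)CC2)cc1` gives < 1000 nM as its reading, which is a limit and not a number. Compound 2 `NC(=O)c1ccc2[nH]c(-c3ccc(OCCC4CCCCN4Cc4ccc(Cl)cc4)cc3)nc2c1` gives 115000 nM as a true number in this assay while compound 1 `COc1ccc(CN2CCCC(COc3ccc(-c4nc5cc(C(N)=O)ccc5[nH]4)cc3)C2)cc1` has "not determined" (no result reported) as its entry.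

Compound 4 `NC(=O)c1ccc2[nH]c(-c3ccc(OCCC4CCN(C(=O)c5ccccc5)CC4)cc3)nc2c1` differs from compound 3 in one place, with benzoyl in place of 4-methoxybenzyl on an amine nitrogen in a ring. Within the data shown here, no measured step between compounds is available as a guide to this change. The expected step of a number no lower from compound 3 to compound 4 (the limit leaves the size open) in this assay is estimated to stay within the usual scatter, with no firm direction. Compound 4 is estimated at 1000 nM with a range from 300 nM to 8000 nM as the expected reading.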

Compound 4, solubility: 3000 nM
Estimate against measurement, compound 4: 3.0-fold (0.48 log units) below; measured number inside the range.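

In this assay, benzoyl in place of 4-methoxybenzyl on the amine nitrogen in the ring gives an at least 3.0-fold higher number from compound 3 to compound 4 (0.47 log units; beyond the scatter), so this position does respond to the change. Compound 3 stands only at a limit, not a number, and the step therefore has no upper size: the limit of < 1000 nM in this assay, at which 1 of the 4 values shown sits.

The compounds shown leave open whether the carbonyl or the lost methoxy group goes with the step. A 4-methoxybenzoyl or a plain benzyl on that nitrogen would separate the two.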